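The source may hold more compounds than are shown below. What is called first, only, known or untested is meant among the compounds shown, and "the series" means these compounds.

Measured so far in an assay on isolated protein for inhibition of fatty acid synthase (Rattus norvegicus); a lower number here means a stronger inhibitor, a higher number a weaker inhibitor:
compound 1, `Oc1nc2ccc(C(F)(F)F)cc2c(O)c1-c1ccccc1`: > 15000 nM
compound 2, `O=[N+]([O-])c1cc2c(O)c(-c3ccc(F)cc3F)c(O)nc2cc1Cl`: 173 nM

The value of compound 1 is a limit of the assay, not a number; (the limit of > 15000 nM in this assay, at which 1 of the 2 values shown sits). Among the compounds with values here, compound 2 gives the only number among the two, so it stands alone in this assay, and its distance to compound 1 cannot be put as a step, since one side is a limit.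

Compound 3, `O=[N+]([O-])c1cc2c(O)c(-c3nn[nH]n3)c(O)nc2cc1Cl`, is not yet measured. It differs from compound 2 in one place: 2H-tetrazol-5-yl in place of 2,4-difluorophenyl on an aromatic carbon. The core with its nitro and chloro groups is kept.

Within the data shown here, no step between measured compounds is available, so the size of this change has no precedent. Replacing a six-membered aromatic ring of carbon only by a five-membered aromatic ring with four hetero atoms is a large change in one place, and it is expected to weaken inhibition in this assay beyond the scatter. For compound 3 the estimate is 3000 nM, with a range from 500 nM to 15000 nM. The step expected from this is a 17-fold higher number from compound 2 to compound 3 (1.24 log units; beyond the scatter). A limit-only read-out for compound 3 is a real possibility.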

Compound 3, half-maximal inhibitory concentration: 2600 nM
Estimate against measurement, compound 3: 1.2-fold (0.06 log units) above; measured number inside the range.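

In this assay, within the data shown here, replacing 2,4-difluorophenyl with 2H-tetrazol-5-yl on the aromatic carbon ortho to two hydroxy groups gives a 15-fold higher number from compound 2 to compound 3 (1.18 log units; beyond the scatter), the first readable step and a large one. Inhibition is weakened but not lost at this place, as compound 3 still gives a number, 2600 nM, with a five-membered aromatic ring with 4 hetero atoms in place of the six-membered aromatic ring of carbon only. Nothing measured here gives a cause for this step.

This single step changes the ring size, the hetero atoms and the hydrogen-bond donors and acceptors together, so the compounds shown cannot separate their contributions, and any step involving compound 1 cannot be read, as its value is a limit of the assay and it differs from the others in more than one place. Open too, going by these compounds, is how a carboxylic acid or an unsubstituted phenyl at this carbon, on the core with its nitro and chloro groups, would compare with compound 2 and compound 3.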